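A new phenyl group on compound 3

A few compounds are considered here, and "the series" means these few. Any claim that something is new, unique, unknown or untested is made for them only; others in the source may bear on it.

Values measured so far in a functional assay on RT-112 cells (Homo sapiens) for antiproliferative activity, read by MTT assay, with a stated time of 72 h; a higher number here means a weaker inhibitor of growth, a lower number a stronger inhibitor of growth
compound 1 `COc1cc(Nc2ncnc3c(NC(=O)Nc4ccc(C)cc4C)cccc23)cc(OC)c1` gives 1290 nM
compound 2 `COc1cc(Nc2ncnc3c(NC(=O)Nc4ccc(C)c(C)c4)cccc23)cc(OC)c1` gives 8.8 nM
compound 3 `COc1cc(Nc2ncnc3c(NC(=O)Nc4ccc(F)cc4F)cccc23)cc(OC)c1` gives 2460 nM

Compound 3 stands at 2460 nM in the same range as compound 1 and far above compound 2. The next compound, compound 4 `COc1cc(Nc2ncnc3c(NC(=O)Nc4ccc(C(F)(F)F)cc4Cl)cccc23)cc(OC)c1` and not yet measured, keeps the shared core but carries 2-chloro-4-(trifluoromethyl)phenyl in place of 2,4-difluorophenyl on an amide-type nitrogen in the same place.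

Going by the values given here, three measured steps bear on this change. Exchanging 2,4-dimethylphenyl for 3,4-dimethylphenyl gave a 150-fold lower number from compound 1 to compound 2 (2.17 log units; beyond the scatter) and exchanging 3,4-dimethylphenyl for 2,4-difluorophenyl gave a 280-fold higher number from compound 2 to compound 3 (2.45 log units; beyond the scatter) as well, so both of these steps are large. The new group's name numbers its substituents 2 and 4, as in compounds 1 and 3, and not 3 and 4, as in compound 2. The closest guide is therefore a 1.9-fold higher number from compound 1 to compound 3 (0.28 log units; within the scatter) within the scatter, although three compounds are a slim basis and none carries chlorine or trifluoromethyl.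

No step beyond the scatter is therefore expected in this assay here. The expected step is a 1.2-fold lower number from compound 3 to compound 4 (0.09 log units; within the scatter) on this estimate. For compound 4 the estimated value is 2000 nM with an expected range from 600 nM to 7000 nM on this estimate.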

Compound 4, concentration for 50% growth inhibition: 1080 nM
Estimate against measurement, compound 4: 1.9-fold (0.27 log units) above, and the stated range covers the measured number.
By their numbers in this assay, from the lowest: compound 2; then compounds 4, 1 and 3 (each within the scatter of the next, the first and the last beyond it).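

In this assay, going by these compounds alone, 2-chloro-4-(trifluoromethyl)phenyl in place of 2,4-difluorophenyl on an amide-type nitrogen gives a 2.3-fold lower number from compound 3 to compound 4 (0.36 log units; beyond the scatter), so this position takes a group carrying chlorine and trifluoromethyl, neither seen in the earlier compounds, and the number shifts only modestly. Against 2,4-dimethylphenyl the same group gives a 1.2-fold lower number from compound 1 to compound 4 (0.08 log units; within the scatter), whereas against 3,4-dimethylphenyl it gives a 120-fold higher number from compound 2 to compound 4 (2.09 log units; beyond the scatter), so three groups numbered 2 and 4 now lie far above the single group numbered 3 and 4, and compound 4 gives this pattern a third member with no compound going against it. Nothing available here explains why these groups give these numbers.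

With only one group numbered 3 and 4, the compounds shown cannot separate the numbering of the substituents from the particular substituents on compound 2. A 3,4-difluorophenyl or 3-chloro-4-(trifluoromethyl)phenyl group would test this directly, and an unsubstituted phenyl group would show what the substituents add at this position.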